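Changing the acid-bearing ring of a weak modulator

This account rests on a few compounds, and the source may have more. Where it says the series, first, only, none or still open, it means among the compounds named here.

Measured so far:
- compound 1, `Cc1c(OCCCCOc2ccc(C(=O)O)cc2Cl)ccc(C(=O)CC2CCCC2)c1O`: > 10000 nM
- compound 2, `Cc1c(OCCCCOc2ccc(C(=O)O)cc2Cl)ccc(C(=O)CC(C)C)c1O`: 1140 nM
- compound 3, `CCC(=O)c1ccc(OCCCCOc2ccc(C(=O)O)cc2C)c(C)c1O`: "not determined" (no result reported)

All three compounds share a core and were tested in an assay on HEK293 cells for positive allosteric modulation of metabotropic glutamate receptor 3 (Rattus norvegicus), read by thallium flux, with a stated time of 2.5 min; on this read-out lower numbers stand for an effect already at smaller amounts and higher numbers for an effect only at larger amounts of compound. For compound 1 only a limit of the assay is known, > 10000 nM, so compound 1 sits at the limit of > 10000 nM in this assay, at which 1 of the 3 values shown sits, rather than at a measured number. For compound 3 no result was reported. For the measured compounds named here, the only measured step, an at least 8.7-fold lower number from compound 1 to compound 2 (0.94 log units; beyond the scatter), concerns the chain next to the carbonyl and not the acid-bearing ring.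

Compound 4, `Cc1c(OCCCCOc2ccc(F)c(C(=O)O)c2)ccc(C(=O)CC2CCCC2)c1O`, differs from compound 1 in that ring alone: 3-carboxy-4-fluorophenyl in place of 4-carboxy-2-chlorophenyl on an oxygen on a saturated carbon. No measured step touches this part of the molecule, so there is nothing among the numbers shown that bears on the change, in either direction. Given that compound 1 is itself at the limit, the expectation is that compound 4 again shows no measurable effect, with an estimated step that the limit leaves unreadable from compound 1 to compound 4. Compound 4 is therefore expected at about 15000 nM, within 3000 nM to 60000 nM, most likely reported only as a limit.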

Compound 4, half-maximal effective concentration: 2490 nM
For compound 4 the middle estimate is 6.0-fold (0.78 log units) above the measured one, and the stated range ends above it.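

The acid-bearing ring turns out to matter in this assay: with the cyclopentyl group kept, 3-carboxy-4-fluorophenyl in place of 4-carboxy-2-chlorophenyl gives an at least 4.0-fold lower number from compound 1 to compound 4 (0.60 log units; beyond the scatter). The cyclopentyl group therefore does not by itself hold a compound at the limit, and the change to isopropyl is no longer the only single change shown that yields a measured number. The full size of the step cannot be read, because compound 1 gives only a limit and not a number: the limit of > 10000 nM in this assay, at which 1 of the 4 values shown sits.

This ring change alters where the carboxy group sits and replaces chlorine with fluorine in one move, and the compounds shown do not separate the two. Also open, as far as these compounds go, are how 3-carboxy-4-fluorophenyl behaves with the isopropyl group of compound 2, and what a nitrile or a methoxy group in place of the fluorine would give.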